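The source may hold more compounds than are shown below. What is called first, only, known or untested is meant among the compounds shown, and "the series" means these compounds.

Of the compounds shown here, two have numbers so far in an ADME assay on L6 cells (Rattus norvegicus) for cytotoxicity, read by resazurin assay, with a stated time of 72 h; a higher number here means a weaker inhibitor, a lower number a stronger inhibitor. Compound 1 `Cc1occc1C(=O)NC(=O)c1ccccc1O` gives 16 ug/mL, and compound 2 `Cc1ccc(C(=O)NC(=O)c2ccccc2O)cc1` gives 46 ug/mL, the higher of the two numbers, with a gap to compound 1 that lies beyond the scatter. Compound 3 `CC(C)(C)c1ccc(C(=O)NC(=O)c2ccccc2O)cc1` has not yet been measured. It differs from compound 2 by tert-butyl in place of methyl on an aromatic carbon. For the measured compounds named here, no measured pair shows a change at this place, so the only anchor is compound 2 at 46 ug/mL, and any expectation is loose. A modest move to a lower number is expected, near the scatter rather than well beyond it. The expected change is a 1.8-fold lower number from compound 2 to compound 3 (0.25 log units; within the scatter). The estimate for compound 3 is 26 ug/mL, with an expected range of 9 ug/mL to 70 ug/mL.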

Compound 3, half-maximal inhibitory concentration: 2.3 ug/mL
The estimate for compound 3 lay 11-fold (1.05 log units) above the measured number, and the stated range ends above it.
By their numbers in this assay, from the lowest: compound 3; then compound 1; then compound 2.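

In this assay, the step from methyl to tert-butyl on an aromatic carbon para to a large group gives a 20-fold lower number from compound 2 to compound 3 (1.30 log units; beyond the scatter), so this place is far from silent in this read-out. For the compounds shown here, it is the only measured change at this place, and that single substitution lies well beyond the scatter. Nothing measured here bears on what lies behind the step.

From the compounds shown here alone, with one pair, it remains open whether the number falls steadily as carbons are added at this place or whether the branched tert-butyl group is specifically required. Ethyl, isopropyl and a straight butyl chain would separate those two readings, while an amine or a carboxylic acid at the same place would show whether the step holds beyond carbon-only groups.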